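The compounds below may be only part of what the source reports. "The series", "measured", "known", "first", "only" and "open" are said of these compounds alone.

Compound 1, `O=S(=O)(c1ccc(F)c(Cl)c1)c1cnc2cc(F)ccc2c1-c1ccc(F)cc1`, with 21 nM; compound 2, `O=S(=O)(c1cc(Cl)cc(Cl)c1)c1cnc2cc(F)ccc2c1-c1cccc(F)c1`, with 35 nM.

Both were tested in a functional assay on cells for negative allosteric modulation of metabotropic glutamate receptor 5 (Homo sapiens), read by fluorescence and calcium flux, with a stated time of 20 min; on this read-out higher numbers stand for weaker inhibition and lower numbers for stronger inhibition. Compound 2 gives 35 nM, and that number sits within the usual scatter of compound 1, so nothing separates the two. Compound 3, `O=S(=O)(c1cc(Cl)cc(Cl)c1)c1cnc2cc(F)ccc2c1-c1ccc(F)cc1`, is not yet measured. The change from compound 2 is 4-fluorophenyl in place of 3-fluorophenyl on an aromatic carbon, which gives compound 3 the same fluorophenyl as compound 1. Since compound 1 gives 21 nM, no step beyond the scatter is expected in this assay: the expected step is a 1.4-fold lower number from compound 2 to compound 3 (0.15 log units; within the scatter). Compound 3 is therefore estimated at 25 nM, in a range from 10 nM to 60 nM.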

Compound 3, half-maximal inhibitory concentration: 25 nM
For compound 3 middle estimate and measured number coincide at the digits printed; the measured number falls inside the stated range.
By their numbers in this assay, from the lowest: compounds 1, 3 and 2 (each within the scatter of the next).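

In this assay, compound 3 links the two earlier compounds, which differed from each other in two places, so each place can now be read alone. On the aromatic carbon opposite the ring nitrogen, 4-fluorophenyl in place of 3-fluorophenyl gives a 1.4-fold lower number from compound 2 to compound 3 (0.15 log units; within the scatter), and on the sulfonyl sulfur, 3,5-dichlorophenyl in place of 3-chloro-4-fluorophenyl gives a 1.2-fold higher number from compound 1 to compound 3 (0.08 log units; within the scatter), so neither change separates the compounds. Nothing measured here offers an explanation for this. The compounds shown leave open whether a different kind of group on that aromatic carbon, such as an amine or a carboxylic acid, would also stay within the scatter.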